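A few compounds are considered here, and "the series" means these few. Any claim that something is new, unique, unknown or untested is made for them only; others in the source may bear on it.

Compound 1 `C=CC1=C(C(=O)NCc2ccc(Cl)cc2)C(c2ccc(OC)c(OC)c2)OC1` gives, in a functional assay on HeLa cells (Homo sapiens) for cytotoxicity, read by MTT assay, with a stated time of 24 h (on this read-out higher numbers stand for weaker inhibition and lower numbers for stronger inhibition), > 100000 nM, which is a limit of the assay and not a number.
Compound 2 `C=CC1=C(C(=O)NCCCCC)C(c2ccc(OC)cc2)OC1` gives in this assay > 100000 nM, again only a limit.
Compound 3 `C=CC1=C(C(=O)NCc2ccc(Cl)cc2)C(c2ccc(OC)cc2)OC1` gives in this assay > 100000 nM, once more a limit.

Compound 3 thus stands at the limit of > 100000 nM in this assay, at which 3 of the 3 values shown sit, and nothing in the numbers sets it apart from the others. Two measured steps lead to it. Hydrogen in place of methoxy on an aromatic carbon gives a step that the two limits leave unreadable from compound 1 to compound 3. The other step, in which the butyl chain becomes a 4-chlorophenyl group, gives a step that the two limits leave unreadable from compound 2 to compound 3. Neither step has a readable size, so neither tells in which direction a further change at the amide-type nitrogen might move the read-out.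

Compound 4 `C=CC1=C(C(=O)NC(C)(C)C)C(c2ccc(OC)cc2)OC1` differs from compound 3 in one place: tert-butyl in place of 4-chlorobenzyl on an amide-type nitrogen. The tert-butyl group is smaller than the 4-chlorobenzyl group it replaces and carries no ring, but the measured steps offer no basis for expecting a change beyond the scatter in this assay, in either direction.

Compound 4 is therefore expected to give 150000 nM, with a range from 50000 nM to 500000 nM, most probably reported once more only as a limit. This estimate means an expected step that the limit leaves unreadable from compound 3 to compound 4.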

Compound 4, half-maximal inhibitory concentration: > 100000 nM
Compound 4: only a limit was reported; the forecaster's own chance of this, stated with the estimate: 85%; the middle value is on the limit's open side.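

Compound 4, like compound 2 and compound 3, gives only a limit in this assay, so no step from either compound to compound 4 can be read: the limit of > 100000 nM in this assay, at which 4 of the 4 values shown sit.

The compounds shown leave open what size these changes on the amide-type nitrogen have, and at what concentration, if any, these compounds reach half-maximal inhibition.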